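The source may report more compounds than this note shows. Statements on the series, on what has been measured and on what is new or still open speak of the compounds shown alone.

Compound 1 `Cn1cncc1CN1CC(N(CC2CCN(C(=O)C(C)(C)C)CC2)S(=O)(=O)c2ccccn2)Cc2cc(C#N)ccc21`, compound 2 `CCC(=O)N1CCC(CN(C2Cc3cc(C#N)ccc3N(Cc3cncn3C)C2)S(=O)(=O)c2ccccn2)CC1` and compound 3 `Cn1cncc1CN1CC(N(CC2CCN(C(=O)CC(C)(C)C)CC2)S(=O)(=O)c2ccccn2)Cc2cc(C#N)ccc21` share one core and differ only in the group on the carbonyl carbon. In an ADME assay on Caco-2 cells (Homo sapiens) for permeability, in the apical to basolateral direction (a lower number here means that the compound crosses the layer more slowly, a higher number that the compound crosses the layer faster), compound 1 gives 0.5 10^-6 cm/s, compound 2 gives 0.5 10^-6 cm/s and compound 3 gives 0.5 10^-6 cm/s. Compound 2 thus stands level with the other two: no change at the digits printed from compound 1 to compound 2 (within the scatter), no change at the digits printed from compound 1 to compound 3 (within the scatter) and no change at the digits printed from compound 2 to compound 3 (within the scatter). Compound 4 `CCS(=O)(=O)N1CCC(CN(C2Cc3cc(C#N)ccc3N(Cc3cncn3C)C2)S(=O)(=O)c2ccccn2)CC1` has not yet been measured. It differs from compound 2 in one place: ethylsulfonyl in place of propanoyl on an amine nitrogen in a ring. For the measured compounds named here, none of the measured steps touches the carbonyl itself; each only exchanges one alkyl for another on it, and none moved the read-out beyond the scatter. Going by the values given here, the step to compound 4 therefore has no direct precedent among them, and it is weighed on the grounds that all three measured values sit together. It is expected that compound 4 stays close to compound 2, with no change at the digits printed from compound 2 to compound 4 (within the scatter) amounting to no step beyond the scatter. The estimate for compound 4 is 0.5 10^-6 cm/s, between 0.2 10^-6 cm/s and 1.2 10^-6 cm/s.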

Compound 4, apparent permeability: 0.1 10^-6 cm/s
The estimate for compound 4 lay 5.0-fold (0.70 log units) above the measured number; the measured number lies below the stated range.
By their numbers in this assay, from the lowest: compound 4; then compounds 1, 2 and 3 (each within the scatter of the next).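

Ethylsulfonyl in place of a carbonyl-linked group on this amine nitrogen in a ring is the first change shown to move the number in this assay, with a 5.0-fold lower number from compound 2 to compound 4 (0.70 log units; beyond the scatter), and the same exchange reads alike against the other two, with a 5.0-fold lower number from compound 3 to compound 4 (0.70 log units; beyond the scatter) and a 5.0-fold lower number from compound 1 to compound 4 (0.70 log units; beyond the scatter). The position therefore tolerated the alkyl exchanges among compound 1, compound 2 and compound 3 without a step beyond the scatter, yet it responds once the carbonyl itself is replaced by a sulfonyl. Nothing given here accounts for this step.

With ethylsulfonyl as the only sulfonyl group shown, it remains open whether methylsulfonyl or phenylsulfonyl would give a number like that of compound 4. Going by these compounds, it is equally open whether a urea or a carbamate on the same nitrogen would stay level with compound 2.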